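A few compounds are considered here, and "the series" means these few. Any claim that something is new, unique, unknown or untested is made for them only; others in the source may bear on it.

Compound 1, with the structure `CC(C)(C)c1ccc(-c2cn(CC3=C(Cl)c4ccc(-c5cccs5)nc4CC3)nn2)cc1`, was tested in an ADME assay on MDCK cells (Canis lupus familiaris) for cytotoxicity, read by MTT assay, with a stated time of 48 h (a higher number here means that more compound is tolerated, a lower number that less compound is tolerated), where compound 1 gives 172 ug/mL. This is the lowest of the two numbers recorded so far, though its nearest neighbour sits within the scatter: compound 2, of structure `Fc1ccc(-c2cn(CC3=C(Cl)c4ccc(-c5cccs5)nc4CC3)nn2)c(F)c1`, gives 188 ug/mL in this assay, and the step of a 1.1-fold higher number from compound 1 to compound 2 (0.04 log units; within the scatter) is too small to count as a real difference. The next compound, compound 3, has the structure `FC(F)(F)Oc1ccc(-c2cn(CC3=C(Cl)c4ccc(-c5cccs5)nc4CC3)nn2)cc1` and differs from compound 1 only in one place: trifluoromethoxy in place of tert-butyl on an aromatic carbon. Among the compounds with values here, the one measured step that bears on a swap at this position, a 1.1-fold higher number from compound 1 to compound 2 (0.04 log units; within the scatter), was within the scatter, so a change at the same spot is expected to move this assay little. For compound 3 the estimated step is therefore a 1.0-fold higher number from compound 1 to compound 3 (0.01 log units; within the scatter), no larger than the scatter. Compound 3 is thus expected to give about 175 ug/mL, within a range of 100 ug/mL to 310 ug/mL.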

Compound 3, half-maximal cytotoxic concentration: > 300 ug/mL
Compound 3 ended at the assay's limit (the forecaster's own chance of this, stated with the estimate: 10%); at least 1.7-fold (0.23 log units) between middle value and limit.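

In this assay compound 3 gives > 300 ug/mL, which is a limit and not a number: the limit of > 300 ug/mL in this assay, at which 1 of the 3 values shown sits. Trifluoromethoxy in place of tert-butyl gives an at least 1.7-fold higher number from compound 1 to compound 3 (0.24 log units; that floor lies within the scatter), and 4-(trifluoromethoxy)phenyl in place of 2,4-difluorophenyl gives an at least 1.5-fold higher number from compound 2 to compound 3 (0.20 log units; that floor lies within the scatter). Neither floor proves a real change, but unlike the earlier step between compound 1 and compound 2, these two steps have no upper bound, so this position can no longer be read as one where a swap leaves the number flat.

From the compounds shown here alone, how far compound 3 truly lies from compound 1 and compound 2 remains open, as does whether its number would clear the scatter. Also open, going by these compounds, is how an amine, a carboxylic acid or a longer alkyl chain in place of tert-butyl would read in this assay.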